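The source may report more compounds than this note shows. Statements on the series, on what has been measured and on what is new or still open speak of the compounds shown alone.

Of the compounds shown here, three sharing one core have been tested in an ADME assay on MT4 cells (Homo sapiens) for cytotoxicity, read by MTT assay; on this read-out higher numbers stand for lower toxicity in this test and lower numbers for higher toxicity in this test. Compound 1 `O=C1c2ccccc2C(=O)N1CCOC(=S)N(C(=O)c1ccc([N+](=O)[O-])cc1)c1ccc(Cl)cc1` gives > 100000 nM, which is a limit of the assay and not a number. Compound 2 `COc1cccc(OC)c1C(=O)N(C(=S)OCCN1C(=O)c2ccccc2C1=O)c1ccc(C)cc1` gives 36000 nM. Compound 3 `O=C1c2ccccc2C(=O)N1CCOC(=S)N(C(=O)c1ccco1)c1cccc(Cl)c1Cl` gives 100000 nM, the higher of the two actual numbers and beyond the scatter from compound 2. Compound 4 `O=C1c2ccccc2C(=O)N1CCOC(=S)N(C(=O)c1ccco1)c1ccc(Cl)cc1Cl` differs from compound 3 in one place: 2,4-dichlorophenyl in place of 2,3-dichlorophenyl on an amide-type nitrogen, with 2,4-dichlorophenyl in place of 2,3-dichlorophenyl on an amide-type nitrogen. Within the data shown here, no measured pair shows such a change, so the 100000 nM of compound 3 is the best guide. The expected 1.3-fold lower number from compound 3 to compound 4 (0.10 log units; within the scatter) in this assay lies within the scatter. Compound 4 is estimated at 80000 nM, with an expected range from 30000 nM to 100000 nM.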

Compound 4, half-maximal cytotoxic concentration: > 100000 nM
Compound 4: only a limit was reported (the forecaster's own chance of this, stated with the estimate: 40%); middle value at least 1.2-fold (0.09 log units) from the limit.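

On the amide-type nitrogen, 2,4-dichlorophenyl in place of 2,3-dichlorophenyl gives the only one-place comparison shown in this assay: a number no lower from compound 3 to compound 4 (the limit leaves the size open). Compound 4 gives > 100000 nM, which is a limit of the assay and not a number. This change therefore brings no lower number, but the size of the step cannot be read, because the value sits at the top of what the test reports: the limit of > 100000 nM in this assay, at which 2 of the 4 values shown sit.

Going by these compounds, it remains open whether a plain phenyl or an aminophenyl on this nitrogen, with the rest of compound 4 kept, would give a readable number in this assay. The same holds for a carboxylic acid in place of the chlorines.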